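From Phenyl to 3,4,5-Trimethoxyphenyl at the Assay Limit

The source may report more compounds than this note shows. Statements on the series, on what has been measured and on what is new or still open speak of the compounds shown alone.

In a functional assay on SMMC-7721 cells (Homo sapiens) for inhibition, read by MTT assay, with a stated time of 48 h (a lower number here means a stronger inhibitor, a higher number a weaker inhibitor), compound 1 (`Cc1c[nH]c2nc(Nc3ccc4c(c3)CC(=O)N4)nc(NCc3cccnc3N(C)S(C)(=O)=O)c12`) gives 18700 nM as a measured number. Compound 2 (`CN(c1ncccc1CNc1nc(Nc2ccccc2)nc2[nH]cc(F)c12)S(C)(=O)=O`) gives > 100000 nM as its result, and this is a limit of the assay and not a number. Of the two, only compound 1 therefore has an exact place on the scale.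

Compound 3 (`COc1cc(Nc2nc(NCc3cccnc3N(C)S(C)(=O)=O)c3c(F)c[nH]c3n2)cc(OC)c1OC`) carries 3,4,5-trimethoxyphenyl in place of phenyl on a nitrogen on an aromatic ring of compound 2 (3,4,5-trimethoxyphenyl in place of phenyl on a nitrogen on an aromatic ring) and is otherwise the same. Among the compounds with values here, no measured pair here shows what such a swap does, so any forecast rests on thin ground. Compound 1 at 18700 nM does show that a number can be reached in this assay with compounds of this kind. A gain in strength is the expected direction, meaning a lower number, although a second result at the limit would be no surprise. The expected change is an at least 2.8-fold lower number from compound 2 to compound 3 (0.45 log units; beyond the scatter) toward stronger inhibition. For compound 3 the estimated value is 35000 nM with 8000 nM to 100000 nM as the expected range.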

Compound 3, half-maximal inhibitory concentration: > 100000 nM
Compound 3: only a limit was reported; the forecaster's own chance of this, stated with the estimate: 35%; at least 2.8-fold (0.45 log units) between middle value and limit.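

Compound 2 and compound 3 both end at a limit of the assay and not at a number, so no step between them can be read: the limit of > 100000 nM in this assay, at which 2 of the 3 values shown sit.

The compounds shown leave open whether 3,4,5-trimethoxyphenyl in place of phenyl changes inhibition at all in this assay, and if it does, in which direction and by how much.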